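Formyl on the core of compound 1

The source may report more compounds than this note shows. Statements on the series, on what has been measured and on what is new or still open speak of the compounds shown alone.

Compound 1 (`Cc1ccc(-c2cc(N)n(-c3cccc(Cl)c3)n2)cc1`) gives > 100000 nM in a functional assay on NPC-TW01 cells (Homo sapiens) for inhibition, read by MTT assay, with a stated time of 72 h (on this read-out lower numbers stand for stronger inhibition of growth and higher numbers for weaker inhibition of growth), which is a limit and not a number. Compound 2 (`Nc1cc(-c2ccc(Cl)cc2)nn1-c1cccc(Cl)c1`) gives > 100000 nM in this assay, also a limit. All the evidence so far therefore sits at one ceiling: the limit of > 100000 nM in this assay, at which 2 of the 2 values shown sit.

Compound 3 (`Cc1ccc(-c2nn(-c3cccc(Cl)c3)c(N)c2C=O)cc1`) is the core of compound 1 with formyl in place of hydrogen on an aromatic carbon. Among the compounds with values here, the only measured step is a step that the two limits leave unreadable from compound 1 to compound 2, a chloro for methyl exchange, and it offers no size to carry over. Since compound 1 gives only the limit > 100000 nM, a weak result remains the likeliest outcome, and a further limit is more likely than not. The expected step is an at least 1.4-fold lower number from compound 1 to compound 3 (0.15 log units; that floor lies within the scatter), toward stronger inhibition of growth if a number is obtained. For compound 3 the estimated value is 70000 nM, with an expected range from 15000 nM to 100000 nM.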

Compound 3, concentration for 50% growth inhibition: > 100000 nM
Compound 3: a limit, no number; the forecaster's own chance of this, stated with the estimate: 60%; middle value at least 1.4-fold (0.15 log units) from the limit.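

In this assay, within the data shown here, compound 3 gives > 100000 nM, a limit and not a number, so no step from compound 1 to compound 3 can be read. The compounds shown leave open whether any change on the shared core yields a readable number: the limit of > 100000 nM in this assay, at which 3 of the 3 values shown sit.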